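Longer Chain Beside the Ring Sulfur: Compound 3

The source may report more compounds than this note shows. Statements on the series, on what has been measured and on what is new or still open speak of the compounds shown alone.

Measured so far:
Compound 1, `CC(C)c1sc(-c2ccccc2)c(-c2ccc(F)cc2)c1/C=C/[C@@H](O)C[C@@H](O)CC(=O)O`: 4.4 nM
Compound 2, `CC(C)c1sc(C(C)C)c(-c2ccc(F)cc2)c1/C=C/[C@@H](O)C[C@@H](O)CC(=O)O`: 26 nM

In an assay on microsomes for inhibition of 3-hydroxy-3-methylglutaryl-coenzyme A reductase (Rattus norvegicus) (a higher number here means a weaker inhibitor, a lower number a stronger inhibitor), compound 2 has the highest of the two numbers, with compound 1 lower by a 5.9-fold higher number from compound 1 to compound 2 (0.77 log units; beyond the scatter). Compound 3, `CCCCCCCCc1sc(C(C)C)c(/C=C/[C@@H](O)C[C@@H](O)CC(=O)O)c1-c1ccc(F)cc1`, differs from compound 2 by octyl in place of isopropyl on an aromatic carbon. Going by the values given here, the only measured step, from phenyl to isopropyl, concerns a different pair of groups, so it gives little guidance for isopropyl to octyl; no clear direction is expected in this assay. Compound 3 is therefore estimated at 35 nM, within 8 nM to 150 nM, a step of a 1.3-fold higher number from compound 2 to compound 3 (0.13 log units; within the scatter).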

Compound 3, half-maximal inhibitory concentration: > 10000 nM
Compound 3: a limit, no number (the forecaster's own chance of this, stated with the estimate: 3%); middle value at least 280-fold (2.45 log units) away from the limit.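

Compound 3 stands at a limit of the assay, not at a number: the limit of > 10000 nM in this assay, at which 1 of the 3 values shown sits.

On this carbon next to the ring sulfur, octyl in place of isopropyl gives an at least 380-fold higher number from compound 2 to compound 3 (2.58 log units; beyond the scatter), and octyl in place of phenyl gives an at least 2200-fold higher number from compound 1 to compound 3 (3.35 log units; beyond the scatter). Going by these compounds alone, the only earlier step at this position was modest, so these results are the first to show that the group here can decide whether the compound registers as an inhibitor at all.

Open, going by these compounds, is how a butyl chain would fare here, and so whether the loss builds with chain length or comes abruptly. Also open, on these data alone, is whether an amine at the end of the octyl chain would change the outcome.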